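A few compounds are considered here, and "the series" means these few. Any claim that something is new, unique, unknown or untested is made for them only; others in the source may bear on it.

Working notes on the series. In a functional assay on cells (CNS carcinoma cell, Homo sapiens) for cytotoxicity, read by sulforhodamine B assay, with a stated time of 48 h (a lower number here means a stronger inhibitor of growth, a higher number a weaker inhibitor of growth), compound 1 (`COc1cc2c(cc1C)NC(=O)/C2=C/c1c(OC)nc2sc(C)cn12`) gives 20400 nM, the lowest of the three numbers at hand. Compound 2 (`COc1nc2sc(C)cn2c1C=C1C(=O)N(C)c2ccccc21`) gives 42400 nM, and compound 3 (`O=C1Nc2ccccc2C1=Cc1c(-c2ccncc2)nc2sccn12`) gives 49700 nM. Both stand beyond the scatter from compound 1, compound 2 being the nearer and compound 3 the further. These three compounds differ from one another in more than one place, so no measured single change is available as a guide.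

Compound 4 (`COc1ccc2c(c1)/C(=C\c1c(OC)nc3sc(C)cn13)C(=O)N2`) is the next to be read. It keeps the core of compound 1 and changes one place: hydrogen in place of methyl on an aromatic carbon, ortho to a methoxy group (hydrogen in place of methyl on an aromatic carbon).

Within the data shown here, with no measured step to go on, the expectation in this assay is no change beyond the scatter. Any drift is expected toward a higher number, with compound 1 the lowest of the three at 20400 nM. Even the several differences separating it from compound 3 at 49700 nM span only a modest width. The expected result is a 1.2-fold higher number from compound 1 to compound 4 (0.07 log units; within the scatter). For compound 4 the estimated value is 24000 nM, with an expected range of 12000 nM to 48000 nM.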

Compound 4, concentration for total growth inhibition: 33600 nM
For compound 4 the middle estimate is 1.4-fold (0.15 log units) below the measured one; the measured number falls inside the stated range.
By their numbers in this assay, from the lowest: compounds 1, 4, 2 and 3 (each within the scatter of the next, the first and the last beyond it).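

Among these compounds, the step at this position is the first measured single change: on an aromatic carbon ortho to a methoxy group, hydrogen in place of methyl gives a 1.6-fold higher number from compound 1 to compound 4 (0.22 log units; within the scatter) in this assay. The earlier compounds shown here differ from one another in more than one place. They could not isolate this methyl group. Here its removal leaves compound 1 and compound 4 indistinguishable in this read-out, so the methyl group is not required to retain the growth inhibition seen with compound 1. Nothing measured on these compounds bears on the reason for this result.

Going by these compounds, only methyl and hydrogen are compared at this carbon, so the reading for other groups there, such as a chlorine atom, an ethyl group or an amine, remains open. Also open, on these data alone, is whether the same replacement would read alike in the settings of compound 2 and compound 3, neither of which has a partner differing from it in this one place.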